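Hydroxy on the triazole side chain across two urea cores

The source may report more compounds than this note shows. Statements on the series, on what has been measured and on what is new or still open speak of the compounds shown alone.

Compound 1 `CC(C)n1cnnc1-c1cccc(NC(=O)Nc2ccc3ccccc3n2)n1` is measured in an assay on isolated protein for inhibition of mitogen-activated protein kinase kinase kinase 6 (Homo sapiens) (a higher number here means a weaker inhibitor, a lower number a stronger inhibitor), where compound 1 gives 2340 nM. Compound 3 `C[C@H](CO)n1cnnc1-c1cccc(NC(=O)Nc2ccc3ccccc3n2)n1` differs from it by one change, (hydroxy in place of hydrogen on a saturated chain carbon, two bonds along the chain from an aromatic nitrogen), and in this assay compound 3 gives 2860 nM, a step of a 1.2-fold higher number from compound 1 to compound 3 (0.09 log units; within the scatter). Compound 2 `CC(C)n1cnnc1-c1cccc(NC(=O)Nc2cnc3ccccc3n2)n1` carries a different core; how the two cores differ is not broken down here. In this assay compound 2 gives 4860 nM, a higher number than that of compound 1, while its value and that of compound 3 sit close together. Compound 4 `C[C@H](CO)n1cnnc1-c1cccc(NC(=O)Nc2cnc3ccccc3n2)n1` is not yet measured; it differs from compound 2 by hydroxy in place of hydrogen on a saturated chain carbon, two bonds along the chain from an aromatic nitrogen, the same change that turns compound 1 into compound 3. Because the earlier step of a 1.2-fold higher number from compound 1 to compound 3 (0.09 log units; within the scatter) stayed within the usual scatter, the step from compound 2 to compound 4 is expected to be of similar size, about a 1.1-fold higher number from compound 2 to compound 4 (0.05 log units; within the scatter). On that basis, compound 4 is estimated to give roughly 5500 nM in this assay, most likely between 2500 nM and 12000 nM.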

Compound 4, half-maximal inhibitory concentration: > 10000 nM
Compound 4 gave a limit, no number; the forecaster's own chance of this, stated with the estimate: 10%; at least 1.8-fold (0.25 log units) between middle value and limit.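

Going by these compounds, compound 4 gives > 10000 nM in this assay, which is a limit of the assay and not a number, so its true value remains unknown: the limit of > 10000 nM in this assay, at which 1 of the 4 values shown sits. Even so, the hydroxy change on this core gives an at least 2.0-fold higher number from compound 2 to compound 4 (0.31 log units; beyond the scatter), a step beyond the usual scatter, whereas the same change on the core of compound 1 gave a step within it. This does not show that the change truly behaves differently on the two cores, and two pairs could not establish a general rule for the series in any case: the same change on two cores in this assay, a 1.2-fold higher number (0.09 log units; within the scatter) from compound 1 to compound 3 and an at least 2.0-fold higher number (0.31 log units; beyond the scatter) from compound 2 to compound 4; the limit leaves it open whether they differ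

The compounds shown leave open how weak compound 4 really is, and a version of the assay that reads beyond this limit would be needed to settle that. They also leave open how an amine, a carboxylic acid or a longer chain in place of the hydroxy would behave on each of the two cores.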